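Amide Nitrogen Substituent Exchange in an Oral Paw Edema Series

This account rests on a few compounds, and the source may have more. Where it says the series, first, only, none or still open, it means among the compounds named here.

Measured compounds:
compound 1 `O=C(NC1CCN(Cc2ccccc2)CC1)c1c(O)c2cccnc2n(-c2ccccc2)c1=O` — 1.2%
compound 2 `Cc1ccc(NC(=O)c2c(O)c3cccnc3n(-c3ccccc3)c2=O)cc1` — 2.2%
compound 3 `O=C(Nc1ccc(Cl)cc1)c1c(O)c2cccnc2n(-c2ccccc2)c1=O` — 2.5%

In a functional assay on the whole organism for inhibition, with Rattus norvegicus as the target, read by cytopathic effect and paw edema, at a dose of 100 mg/kg by the oral route (a lower number here means less inhibition, a higher number more inhibition at the dose given (going by the name of the read-out)), compound 3 gives 2.5%, the highest of the three numbers, yet both other compounds lie within the scatter of it. For the measured compounds named here, the only single-place step measured so far is a number 0.3 percentage points higher from compound 2 to compound 3 (within the scatter), so exchanging one group for another on the aromatic ring borne by the amide-type nitrogen left the read-out flat. Compound 1, with a quite different group on that nitrogen, also sits in the same band.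

Compound 4 `O=C(Nc1ccncc1)c1c(O)c2cccnc2n(-c2ccccc2)c1=O` differs from compound 3 by pyridin-4-yl in place of 4-chlorophenyl on an amide-type nitrogen. Nothing measured here bears directly on a pyridin-4-yl group; the flat step seen suggests no movement beyond the scatter in this assay is expected, the step from compound 3 being estimated as no change at the digits printed from compound 3 to compound 4 (within the scatter). Compound 4 is therefore expected to give about 2.5%, between 0% and 10%.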

Compound 4, a percentage reported as inhibition, in the whole organism at one dose (the size of the read-out at that dose, not a potency): 24.3%
Compound 4: the middle estimate sits 21.8 percentage points below what was measured; measured number outside the range, above it.
By their numbers in this assay, from the lowest: compounds 1, 2 and 3 (each within the scatter of the next); then compound 4.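

Pyridin-4-yl on the amide-type nitrogen gives a number 21.8 percentage points higher from compound 3 to compound 4 (beyond the scatter) and a number 22.1 percentage points higher from compound 2 to compound 4 (beyond the scatter) in this assay while chloro in place of methyl on the carbon ring left the read-out flat. This position is therefore not indifferent to every exchange: replacing the carbon-only aromatic ring with one holding a ring nitrogen moves the number where a change of substituent did not. Nothing available accounts for the size of this step.

On these data alone, whether the gain is specific to pyridin-4-yl stays open, as pyridin-3-yl and pyridin-2-yl on the same nitrogen would show. Also open, as far as these compounds go, is how far a plain phenyl or a pyrimidinyl ring would carry it.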